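The compounds below may be only part of what the source reports. "The series", "measured", "known", "first", "only" and "open" are said of these compounds alone.

In a functional assay on NIH3T3 cells (Mus musculus) (a higher number here means that more compound is needed for the effect, a lower number that less compound is needed), compound 3 `Cn1cncc1C(OCc1ccc(C#N)cc1C#CC1(O)CCCCC1)c1ccc(C#N)cc1` gives 1.93 nM, the lowest of the two readable numbers in this set. Compound 2 `Cn1cncc1C(OCc1ccc(C#N)cc1C#Cc1ccc(C#N)cc1)c1ccc(C#N)cc1` gives 11.6 nM, and the comparison is a 6.0-fold lower number from compound 2 to compound 3 (0.78 log units; beyond the scatter). Compound 1 `Cn1cncc1C(OCc1ccc(C#N)cc1C#Cc1ccccn1)c1ccc(C#N)cc1` has only a limit, > 0.1 nM, and not a number. That leaves a step that the limit leaves unreadable from compound 1 to compound 2 and a step that the limit leaves unreadable from compound 1 to compound 3.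

Compound 4 `Cn1cncc1C(OCc1ccc(C#N)cc1/C=C/c1ccccn1)c1ccc(C#N)cc1` takes the series one step further: 2-(pyridin-2-yl)ethenyl in place of 2-(1-hydroxycyclohexyl)ethynyl on an aromatic carbon. In short, 2-(pyridin-2-yl)ethenyl stands in place of 2-(1-hydroxycyclohexyl)ethynyl on an aromatic carbon. Both the linking bond and the end group change in this step.

Within the data shown here, the only sized step that bears on it is a 6.0-fold lower number from compound 2 to compound 3 (0.78 log units; beyond the scatter), which changes the end group on the triple bond and leaves that bond in place. Among the measured compounds shown here, no measured step replaces a triple bond with a double bond, and no compound with a pyridin-2-yl end group has a readable number. A modest move toward a higher number in this assay is therefore expected, taking the size of the step from compound 2 as a guide. The expected change is a 3.1-fold higher number from compound 3 to compound 4 (0.49 log units; beyond the scatter). For compound 4 the estimate is 6 nM, with an expected range of 1.5 nM to 25 nM.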

Compound 4, half-maximal effective concentration: 23.1 nM
Beside the measured number, compound 4's estimate is 3.9-fold (0.59 log units) below it; measured number inside the range.
By their numbers in this assay, from the lowest: compound 3; then compounds 2 and 4 (each within the scatter of the next).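

Among these compounds, at the aromatic carbon meta to a cyano group, this assay now gives a readable number for a double bond carrying an aromatic end group: 2-(pyridin-2-yl)ethenyl in place of 2-(1-hydroxycyclohexyl)ethynyl gives a 12-fold higher number from compound 3 to compound 4 (1.08 log units; beyond the scatter), the largest readable step so far. Set against the other aromatic end group, 2-(pyridin-2-yl)ethenyl in place of 2-(4-cyanophenyl)ethynyl gives a 2.0-fold higher number from compound 2 to compound 4 (0.30 log units; within the scatter), so this change in both the linking bond and the end group leaves no readable separation. Among the three compounds with readable numbers, compound 3, the only one with a non-aromatic end group, now stands apart from both compounds with an aromatic end group, while compound 1 cannot be placed in this pattern.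

Every step from compound 1 cannot be read, including the one to compound 4 that changes only the triple bond to a double bond, because compound 1 carries a limit and not a number: the limit of > 0.1 nM in this assay, at which 1 of the 4 values shown sits.

Also open, as far as these compounds go, is whether the low number of compound 3 goes with the ring or with its hydroxyl, a question that a plain cyclohexyl or a 1-aminocyclohexyl end group on the triple bond would address.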